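From compound 2 to compound 3: a piperazin-1-yl swap

This account rests on a few compounds, and the source may have more. Where it says the series, first, only, none or still open, it means among the compounds named here.

Compound 1 `C=CCOc1ccc(NC(=O)c2ccc(Cl)cc2Cl)cc1C(C)(C)C` was tested in an ADME assay on a cell-free system (serum) for metabolic stability; on this read-out lower numbers stand for a shorter-lived compound and higher numbers for a longer-lived compound. There compound 1 gives > 1 h, a limit of the assay and not a number. Compound 2 `CC(C)(C)c1cc(NC(=O)c2c(Cl)cc(NCc3cccs3)cc2Cl)ccc1O` gives > 1 h, which is also only a limit. Compound 2 therefore stands at the limit of > 1 h in this assay, at which 2 of the 2 values shown sit. Compound 3 `CC(C)(C)c1cc(NC(=O)c2c(Cl)cc(N3CCNCC3)cc2Cl)ccc1O` carries piperazin-1-yl in place of ((thiophen-2-yl)methyl)amino on an aromatic carbon. Within the data shown here, no measured pair shows the effect of such a change, and no shift beyond the scatter is expected in either direction in this assay. The expected step that the limit leaves unreadable from compound 2 to compound 3 is small. For compound 3 the estimated half-life is 1.5 h, with an expected range of 0.7 h to 4 h.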

Compound 3, half-life: > 1 h
Compound 3 was reported as a limit; the forecaster's own chance of this, stated with the estimate: 75%; the middle value is on the limit's open side.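

In this assay, among these compounds, compound 2 and compound 3 both stand only as limits, so no step between them can be read: the limit of > 1 h in this assay, at which 3 of the 3 values shown sit. The compounds shown leave open how long any of them lasts beyond that limit, and whether piperazin-1-yl in place of ((thiophen-2-yl)methyl)amino changes the half-life at all.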